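Removing a Methoxy Group from a Triazole-Bearing Core

A few compounds are considered here, and "the series" means these few. Any claim that something is new, unique, unknown or untested is made for them only; others in the source may bear on it.

Of the compounds shown here, three of a shared core have been tested in a functional assay on HL-60 cells (Homo sapiens) for cytotoxicity, read by MTT assay, with a stated time of 4 days; on this read-out lower numbers stand for stronger inhibition and higher numbers for weaker inhibition. Compound 1 `C=C1C[C@]23C[C@@]1(O)CC[C@H]2c1ccc(OS(=O)(=O)c2ccc(C)cc2)c(C)c1[C@@H]3Cn1cc(-c2ccc(OC)cc2)nn1` gives > 20000 nM, which is a limit of the assay rather than a number. Compound 2 `COc1ccc(-c2cn(C[C@H]3c4c(ccc(O)c4C)[C@@H]4CC[C@@]5(C)C[C@]43CC5=O)nn2)cc1` gives > 20000 nM, again a limit of the assay. Compound 3 `C=C1C[C@]23C[C@@]1(O)CC[C@H]2c1cc(Br)c(O)c(C)c1[C@@H]3Cn1cc(-c2ccccn2)nn1` returns > 20000 nM, also a limit of the assay. Compound 2 thus stands where every value shown stands, at the limit of > 20000 nM in this assay, at which 3 of the 3 values shown sit, and no number separates it from compound 1 or compound 3.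

Compound 4 `Cc1c(O)ccc2c1[C@H](Cn1cc(-c3ccccc3)nn1)[C@@]13CC(=O)[C@@](C)(CC[C@@H]21)C3` has not yet been measured in this assay. It differs from compound 2 at a single place: hydrogen in place of methoxy on an aromatic carbon. The change is a small one, a methoxy lost from an aromatic carbon of the six-membered aromatic ring of carbon only. Within the data shown here, no two measured compounds differ in one place alone, and nothing among them shows how such a change moves the read-out.

With all three values resting on the same limit, compound 4 is expected to sit there as well. The expected step reads a step that the limit leaves unreadable from compound 2 to compound 4, none beyond the scatter. The estimate for compound 4 is 30000 nM, with a range from 10000 nM to 100000 nM, and the most likely outcome is once more a limit rather than a number.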

Compound 4, half-maximal inhibitory concentration: > 20000 nM
Compound 4: only a limit was reported; the forecaster's own chance of this, stated with the estimate: 80%; the middle value does not contradict the limit.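

In this assay compound 4 gives > 20000 nM, which is a limit of the assay and not a number. Compound 2 rests on the same limit, and no step can be read between compound 2 and compound 4. The compounds shown leave open whether the change from 4-methoxyphenyl to phenyl moves the read-out at all.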